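The compounds below may be only part of what the source reports. "The series", "measured", "known", "first", "only" and "open" are said of these compounds alone.

Measured compounds in a functional assay on cells (Melanoma cell, Homo sapiens) for inhibition; a lower number here means a stronger inhibitor of growth, a higher number a weaker inhibitor of growth:

Compound 1, `Cc1cc(-c2nc3n(c2/C=N/NC(=N)N)CCS3)c(C)s1`: 15500 nM
Compound 2, `N=C(N)N/N=C/c1c(-c2ccsc2)nc2sccn12`: 17000 nM

Compound 2 gives the highest of the two numbers in this assay, but its nearest neighbour is compound 1, whose value is within the scatter of repeated measurements, so the two are not distinguishable on the numbers alone. Going by the values given here, no step between two measured compounds that differ in one place is available, so the series holds no measured guide to any single substitution.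

Compound 3, `Cc1cn2c(/C=N/NC(=N)N)c(-c3ccsc3)nc2s1`, differs from compound 2 by methyl in place of hydrogen on an aromatic carbon, the methyl sitting on an aromatic carbon of a five-membered aromatic ring with 1 nitrogen and 1 sulfur, part of a fused system of two rings. Among the compounds with values here, with no comparable step in hand, the expected step from compound 2 to compound 3, a 1.2-fold lower number from compound 2 to compound 3 (0.08 log units; within the scatter), is small and not expected to reach beyond the scatter in either direction. Compound 3 is therefore estimated at 14000 nM in this assay, with a plausible range from 6000 nM to 35000 nM.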

Compound 3, concentration for 50% growth inhibition: 8130 nM
Estimate against measurement, compound 3: 1.7-fold (0.24 log units) above; low and high end bracket the measured number.
By their numbers in this assay, from the lowest: compounds 3, 1 and 2 (each within the scatter of the next, the first and the last beyond it).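

In this assay, going by these compounds alone, methyl in place of hydrogen on an aromatic carbon next to the ring sulfur gives a 2.1-fold lower number from compound 2 to compound 3 (0.32 log units; beyond the scatter) and is the first single-place change that can be read. Though modest, the step lies beyond the scatter, so this position is not silent to substitution, and adding one carbon here does not cost growth inhibition. No measurement at hand bears on the origin of this step.

One methyl is the only substituent shown at this carbon, so it remains open whether an ethyl group, a longer chain, an amine or a carboxylic acid would extend, keep or reverse the step. From the compounds shown here alone, it is also open whether the same methyl change would give a similar step on the core of compound 1.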